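Shifting the fluorine on the aryl group of compound 3

This account rests on a few compounds, and the source may have more. Where it says the series, first, only, none or still open, it means among the compounds named here.

Of the compounds shown here, three with a shared core have been tested in a functional assay on THP-1 cells (Homo sapiens) for inhibition, read by ELISA, with stated times of 1 h and 18 h (a higher number here means a weaker inhibitor, a lower number a stronger inhibitor), and they differ in one group on an aromatic carbon. With cyclopropyl, compound 1 `NC(=O)[C@@H]1[C@H](Nc2nc(Nc3cccc(C(=O)N4CCCC4)c3)ncc2C2CC2)[C@H]2C=C[C@@H]1C2` gives 90 nM. With pyridin-4-yl, compound 2 `NC(=O)[C@@H]1[C@H](Nc2nc(Nc3cccc(C(=O)N4CCCC4)c3)ncc2-c2ccncc2)[C@H]2C=C[C@@H]1C2` gives 320 nM. With 2-fluorophenyl, compound 3 `NC(=O)[C@@H]1[C@H](Nc2nc(Nc3cccc(C(=O)N4CCCC4)c3)ncc2-c2ccccc2F)[C@H]2C=C[C@@H]1C2` gives 130 nM. That value cannot be told apart from the lowest number, as the data show a 1.4-fold higher number from compound 1 to compound 3 (0.16 log units; within the scatter). Against the highest number, they show a 2.5-fold lower number from compound 2 to compound 3 (0.39 log units; beyond the scatter).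

Compound 4 `NC(=O)[C@@H]1[C@H](Nc2nc(Nc3cccc(C(=O)N4CCCC4)c3)ncc2-c2ccc(F)cc2)[C@H]2C=C[C@@H]1C2` keeps the same atoms, with 4-fluorophenyl in place of 2-fluorophenyl on an aromatic carbon. For the measured compounds named here, no measured step moves a fluorine, so the only guide is what exchanging this group has done so far. The data show a 3.6-fold higher number from compound 1 to compound 2 (0.55 log units; beyond the scatter), so even swapping in a different ring gave only a modest step. A shift of one fluorine is therefore expected to give no step beyond the scatter, in neither direction: the expected step is a 1.2-fold higher number from compound 3 to compound 4 (0.06 log units; within the scatter). The estimated value for compound 4 is 150 nM, within an expected range of 60 nM to 380 nM.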

Compound 4, half-maximal inhibitory concentration: 460 nM
The estimate for compound 4 lay 3.1-fold (0.49 log units) below the measured number; measured number outside the range, above it.
By their numbers in this assay, from the lowest: compounds 1 and 3 (each within the scatter of the next); then compounds 2 and 4 (each within the scatter of the next).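

Moving a single fluorine, with no atom gained or lost, is enough to matter at this position: in this assay the shift gives a 3.5-fold higher number from compound 3 to compound 4 (0.55 log units; beyond the scatter) and so counts as a real step, even though the counts printed for the two groups are identical. Setting 4-fluorophenyl against the other groups gives a 1.4-fold higher number from compound 2 to compound 4 (0.16 log units; within the scatter) for pyridin-4-yl, which leaves those two indistinguishable, and a 5.1-fold higher number from compound 1 to compound 4 (0.71 log units; beyond the scatter) for cyclopropyl, so of the three aromatic rings shown only 2-fluorophenyl stays within the scatter of cyclopropyl. Nothing available explains why the place of the fluorine makes this difference.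

The compounds shown leave open whether 2-chlorophenyl or 2-methoxyphenyl would behave like 2-fluorophenyl. They also leave open how an amine or a short alkyl chain would fare on this same aromatic carbon.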